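This account rests on a few compounds, and the source may have more. Where it says the series, first, only, none or still open, it means among the compounds named here.

Compound 2, `CCCC(=O)C1=C(C)NC(=O)NC1c1ccoc1`, sits at the bottom of the range seen so far: in an assay on membranes from CHO cells for displacement of a labelled ligand from adenosine receptor A1 (Homo sapiens), read by scintillation counting, with a stated time of 60 min, tested at 1 uM (a lower number here means less inhibition, a higher number more inhibition at the concentration tested (going by the name of the read-out)), compound 2 gives 1%. Going by the values given here, its only measured neighbour, compound 1, `CC1=C(C(=O)C2CC2)C(c2ccoc2)NC(=O)N1`, gives 1% in this assay, and the step of no change at the digits printed from compound 1 to compound 2 (within the scatter) is the sole step so far recorded on this carbonyl carbon. Compound 3, `CC1=C(C(=O)NC(C)C)C(c2ccoc2)NC(=O)N1`, is not yet measured; it differs from compound 2 in one place: isopropylamino in place of propyl on a carbonyl carbon. Among the compounds with values here, the one step that bears on it, from compound 1 to compound 2, lay within the scatter, but it exchanged one hydrocarbon group for another at the same carbonyl carbon and gives no direct reading on an isopropylamino group entering there. With the inhibition in this assay level between both measured compounds, a step of a number 1 percentage points higher from compound 2 to compound 3 (within the scatter) is expected, none beyond the scatter. Compound 3 is therefore estimated at 2%, in a range from -8% to 12%.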

Compound 3, a percentage reported as inhibition, at one concentration (the size of the read-out at that concentration, not a potency): 1%
Compound 3: the middle estimate sits 1 percentage points above what was measured; low and high end bracket the measured number.
By their numbers in this assay, from the lowest: compounds 1, 2 and 3 (each within the scatter of the next).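

Isopropylamino in place of propyl on a carbonyl carbon, which reads as propylcarbonyl to isopropylcarbamoyl, gives in this assay no change at the digits printed from compound 2 to compound 3 (within the scatter), and isopropylamino in place of cyclopropyl gives no change at the digits printed from compound 1 to compound 3 (within the scatter). This position has now taken a group with a nitrogen and a hydrogen-bond donor as well as the two hydrocarbon groups, and the three compounds remain level in this read-out at the one concentration tested. No measurement shown offers an explanation for this result.

On these data alone, whether any group on this carbonyl carbon can raise the inhibition remains open, for example benzylamino, a longer alkyl chain or a carboxylic acid. With all three values this low, the series also gives no ranking among propyl, cyclopropyl and isopropylamino.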